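A few compounds are considered here, and "the series" means these few. Any claim that something is new, unique, unknown or untested is made for them only; others in the source may bear on it.

Measured so far in an ADME assay on NIH3T3 cells (Mus musculus) for inhibition, read by sulforhodamine B assay, with a stated time of 48 h; on this read-out higher numbers stand for weaker inhibition of growth and lower numbers for stronger inhibition of growth:
compound 1, `COc1cccc(C(=O)NNC(=O)c2ccc3[nH]c(-c4ccc([N+](=O)[O-])s4)nc3c2)c1`: 15.6 ug/mL
compound 2, `COc1cccc(C(=O)NNC(=O)c2ccc3[nH]c(-c4ccc([N+](=O)[O-])o4)nc3c2)c1`: 15.6 ug/mL
compound 3, `O=CNNC(=O)c1ccc2[nH]c(-c3ccc([N+](=O)[O-])o3)nc2c1`: 62.5 ug/mL

Compound 2 stands level with compound 1 at the digits shown, the two together giving the lowest numbers of the three. Its nearest neighbour is compound 1, with no change at the digits printed from compound 1 to compound 2 (within the scatter); its furthest is compound 3, with a 4.0-fold higher number from compound 2 to compound 3 (0.60 log units; beyond the scatter).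

Compound 4, `O=C(NNC(=O)c1ccc2[nH]c(-c3ccc([N+](=O)[O-])o3)nc2c1)c1cccc(Oc2ccccc2)c1`, is yet to be measured in this assay. It differs from compound 2 in one place: phenyl in place of methyl on an oxygen on an aromatic ring. The rest of the molecule is unchanged.

Going by the values given here, no measured step matches this change. The step of no change at the digits printed from compound 1 to compound 2 (within the scatter) concerns the heteroaryl ring and says nothing about the amide end. The step of a 4.0-fold higher number from compound 2 to compound 3 (0.60 log units; beyond the scatter) shows that the outer aromatic ring on the carbonyl carbon matters, but only in the sense that removing it altogether weakens growth inhibition modestly; nothing measured shows what a larger substituent on the oxygen of that ring does. The working expectation is therefore a step of no change at the digits printed from compound 2 to compound 4 (within the scatter) that stays within the scatter, with the range widened to allow a modest move in either direction. Compound 4 is estimated at 15.6 ug/mL, between 7 ug/mL and 35 ug/mL.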

Compound 4, concentration for 50% growth inhibition: > 7.8 ug/mL
Compound 4 ended at the assay's limit (the forecaster's own chance of this, stated with the estimate: 5%); the middle value does not contradict the limit.
By their numbers in this assay, from the lowest: compounds 1 and 2 (each within the scatter of the next); then compound 3.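

Compound 4 stands at a limit of this assay, not at a number: the limit of > 7.8 ug/mL in this assay, at which 1 of the 4 values shown sits.

Going by these compounds alone, no step from compound 2 to compound 4 can be read from this result. The compounds shown leave open how far, and in which direction, phenoxy in place of methoxy moves growth inhibition.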